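Swapping trifluoromethyl for a methoxy-bearing chain

This account rests on a few compounds, and the source may have more. Where it says the series, first, only, none or still open, it means among the compounds named here.

Three amides share a core in which a substituted benzoyl group is joined through an amide to a benzylic amine carrying a sulfonamide. Compound 1 `CC(C)S(=O)(=O)Nc1ccc(CNC(=O)c2ccc(C(C)(C)C)cc2)c(Cl)c1`, compound 2 `CC(C)(C)c1ccc(C(=O)NCc2c(F)cc(NS(C)(=O)=O)cc2F)cc1` and compound 3 `CS(=O)(=O)Nc1ccc(CNC(=O)c2ccc(C(F)(F)F)cc2)c(Cl)c1` were all examined in an ADME assay on microsomes from liver (Rattus norvegicus, strain Sprague-Dawley) for metabolic stability, read by HPLC, using NADPH, with stated times of 5 min and 60 min, tested at 10 uM; on this read-out higher numbers stand for a longer-lived compound and lower numbers for a shorter-lived compound. Compound 1 gives 0.983 h, compound 2 gives 2.42 h and compound 3 gives 2.43 h. Compound 3 thus stands at the highest number of the three, but its gap to compound 2 is within the scatter, so no order between those two can be claimed; only compound 1 lies clearly lower, beyond the scatter.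

Compound 4 `COC(C)(C)c1ccc(C(=O)NCc2ccc(NS(C)(=O)=O)cc2Cl)cc1` has not yet been measured in this assay. It differs from compound 3 in one place: 1-methoxy-1-methylethyl in place of trifluoromethyl on an aromatic carbon. For the measured compounds named here, no measured pair in this set shows this change, so the size of the step is uncertain. The half-life of compound 4 is expected to move downward from that of compound 3 by a 2.4-fold lower number from compound 3 to compound 4 (0.39 log units; beyond the scatter), a step beyond the scatter. The estimate for compound 4 in this assay is 1 h, with a range from 0.4 h to 2.5 h.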

Compound 4, half-life: 0.917 h
Beside the measured number, compound 4's estimate is 1.1-fold (0.04 log units) above it; measured number inside the range.
By their numbers in this assay, from the lowest: compounds 4 and 1 (each within the scatter of the next); then compounds 2 and 3 (each within the scatter of the next).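

For the compounds shown here, at the aromatic carbon para to a large group, the earlier compounds offered no pair differing in one place, so the effect of a substituent there could not be read. In this assay, 1-methoxy-1-methylethyl in place of trifluoromethyl now gives a 2.6-fold lower number from compound 3 to compound 4 (0.42 log units; beyond the scatter) as the first such reading, showing that the half-life depends on which of these two groups sits at this position. Nothing available explains why the half-life shifts with this change.

As far as these compounds go, with a single pair, it remains open whether the step follows the oxygen of the incoming chain or the chain as a whole. From the compounds shown here alone, how a nitrile, a carboxylic acid or a longer chain at the same place would compare with trifluoromethyl also remains open.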